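This account rests on a few compounds, and the source may have more. Where it says the series, first, only, none or still open, it means among the compounds named here.

Series notes. In a functional assay on aorta (Rattus norvegicus, strain Wistar) for inhibition (a higher number here means that more compound is needed for the effect, a lower number that less compound is needed), compound 1 `O=C(CO[N+](=O)[O-])NNC(=O)c1ccc(-n2[nH]c(=O)cc2-c2ccc([N+](=O)[O-])cc2)cc1` gives 49.1 ug/mL, compound 2 `COc1ccccc1-c1cc(=O)[nH]n1-c1ccc(C(=O)NNC(=O)CO[N+](=O)[O-])cc1` gives 66.9 ug/mL, and compound 3 `CCOC(=O)c1c(-c2ccc([N+](=O)[O-])cc2)n(-c2ccc(C(=O)NNC(=O)CO[N+](=O)[O-])cc2)[nH]c1=O` gives 28.2 ug/mL; compound 3 holds the lowest of the three numbers, within the scatter of compound 1 and beyond it only against compound 2. Compound 4 `CCOC(=O)c1c(-c2ccccc2OC)n(-c2ccc(C(=O)NNC(=O)CO[N+](=O)[O-])cc2)[nH]c1=O` differs from compound 3 by 2-methoxyphenyl in place of 4-nitrophenyl on an aromatic carbon. The same exchange was seen once, as a 1.4-fold higher number from compound 1 to compound 2 (0.13 log units; within the scatter), within the scatter; the other step, a 1.7-fold lower number from compound 1 to compound 3 (0.24 log units; within the scatter), also stayed within it. A comparable small shift is therefore expected in this assay, with a somewhat higher number or none beyond the scatter, as a 1.3-fold higher number from compound 3 to compound 4 (0.13 log units; within the scatter). Compound 4 is estimated at 38 ug/mL, in the range 22 ug/mL to 68 ug/mL.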

Compound 4, half-maximal effective concentration: 63.1 ug/mL
Compound 4: the middle estimate sits 1.7-fold (0.22 log units) below what was measured; measured number inside the range.
By their numbers in this assay, from the lowest: compounds 3, 1, 4 and 2 (each within the scatter of the next, the first and the last beyond it).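

In this assay, the exchange of 4-nitrophenyl for 2-methoxyphenyl now gives a step beyond the scatter, a 2.2-fold higher number from compound 3 to compound 4 (0.35 log units; beyond the scatter), on the core bearing ethoxycarbonyl, but it cannot be separated from the earlier step on the core without that group: the same change on two cores in this assay, a 1.4-fold higher number (0.13 log units; within the scatter) from compound 1 to compound 2 and a 2.2-fold higher number (0.35 log units; beyond the scatter) from compound 3 to compound 4, 1.6-fold (0.22 log units) apart, within the scatter of two such steps. Ethoxycarbonyl in place of hydrogen, a 1.1-fold lower number from compound 2 to compound 4 (0.03 log units; within the scatter), stays within the scatter with 2-methoxyphenyl as well, and again the two cores do not separate: the same change on two cores in this assay, a 1.7-fold lower number (0.24 log units; within the scatter) from compound 1 to compound 3 and a 1.1-fold lower number (0.03 log units; within the scatter) from compound 2 to compound 4, 1.6-fold (0.22 log units) apart, within the scatter of two such steps. Neither change shows a dependence on the other across these four compounds. Still open, on these data alone, is how a carboxylic acid in place of ethoxycarbonyl, or an unsubstituted phenyl in place of 2-methoxyphenyl, would read.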